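Swapping the ring on the core nitrogen: permeability outlook

The source may report more compounds than this note shows. Statements on the series, on what has been measured and on what is new or still open speak of the compounds shown alone.

Compound 1, `OCCCNc1ncnc2c1c(-c1ccccc1)c(-c1ccccc1)n2Cc1ccccc1`: "nd" (no result reported)
Compound 2, `N=c1c2c(-c3ccccc3)c(-c3ccccc3)n(Cc3ccccc3)c2ncn1CCNc1ccncc1`: 445 10^-6 cm/s
Compound 3, `COc1ccc(-c2c(-c3ccc(OC)cc3)n(Cc3ccccc3)c3ncn(CC4CCOC4)c(=N)c23)cc1`: > 1000 10^-6 cm/s

All three were put through an ADME assay for permeability, using PAMPA, with a stated time of 30 min, at pH 7.4; a lower number here means that the compound crosses the layer more slowly, a higher number that the compound crosses the layer faster. Compound 1 has no result recorded, so it carries no number here. Compound 2 gives a clear value in this assay, namely 445 10^-6 cm/s. Compound 3 gives only > 1000 10^-6 cm/s in this assay, which is a limit of the measurement and not a number. Compound 3 therefore stands at the limit of > 1000 10^-6 cm/s in this assay, at which 1 of the 3 values shown sits, with one further entry that has no single number, so its exact place cannot be read off.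

The next compound, compound 4, is `COc1ccc(-c2c(-c3ccc(OC)cc3)n(Cc3ccccc3)c3ncn([C@H]4CC[C@H](OC)CC4)c(=N)c23)cc1`. It differs from compound 3 in one place: 4-methoxycyclohexyl in place of (oxolan-3-yl)methyl on an aromatic nitrogen. Among the compounds with values here, no measured pair of compounds shows what such a change does in this assay, so the expectation rests only on where compound 3 sits. The step is expected to be a number no higher from compound 3 to compound 4 (the limit leaves the size open), which means none beyond the scatter. Compound 4 is estimated at 1000 10^-6 cm/s, in the range 500 10^-6 cm/s to 1600 10^-6 cm/s, and it is expected that this assay may again report only a limit.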

Compound 4, apparent permeability: > 1000 10^-6 cm/s
Compound 4 ended at the assay's limit (the forecaster's own chance of this, stated with the estimate: 65%); the middle value lies on the limit itself.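

Within the data shown here, compound 3 and compound 4 both ended at a limit of the measurement rather than at a number, so no step between them can be read. The compounds shown leave open how their true values compare, and whether 4-methoxycyclohexyl in place of (oxolan-3-yl)methyl changes anything.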